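The compounds below may be only part of what the source reports. "The series", "measured", "known", "first", "only" and "open" are said of these compounds alone.

Compound 1, `O=C(/C=C/CCCCCCc1ccccc1)NCc1ccccc1`, gives a limit of > 100000 nM in a functional assay on PANC-1 cells (Homo sapiens) for cytotoxicity, read by WST assay, with a stated time of 24 h; a lower number here means a stronger inhibitor, a higher number a weaker inhibitor. Compound 2, `O=C(/C=C/CCCCCCc1ccccc1)N1CCC(O)CC1`, gives a limit of > 100000 nM in this assay. Compound 3, `O=C(CCCCCCCCCc1ccccc1)N1CCCCC1`, gives a limit of > 100000 nM in this assay.

Compound 3 therefore stands at the edge of what the method can read, as do the two other compounds shown; all three values sit at the limit of > 100000 nM in this assay, at which 3 of the 3 values shown sit. Going by the values given here, the one step that can be stated among them, a step that the two limits leave unreadable from compound 1 to compound 2, runs between two limits and has no readable size. Compound 4, `O=C(CCCCCCCCc1ccc(Cl)cc1)N1CCCCC1`, differs from compound 3 in one place: 4-chlorophenyl in place of benzyl on a saturated chain carbon, eight bonds along the chain from a carbonyl carbon. No measured step bears on this exchange; the single step shown concerns the amide side of the shared core instead. With every value shown at the limit, compound 4 is expected to give no reading in this assay either, and a number no higher from compound 3 to compound 4 (the limit leaves the size open) is estimated as no step beyond the scatter. The estimate for compound 4 in this assay is 100000 nM, within 30000 nM to 300000 nM, most likely reported only as a limit.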

Compound 4, half-maximal inhibitory concentration: 65500 nM
The estimate for compound 4 lay 1.5-fold (0.18 log units) above the measured number; measured number inside the range.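

Going by these compounds alone, compound 4 is the first compound in this assay to give a number rather than a limit, so this end of the chain is the first place where a change yields a reading: the limit of > 100000 nM in this assay, at which 3 of the 4 values shown sit. The exchange of benzyl for 4-chlorophenyl, on a saturated chain carbon, eight bonds along the chain from a carbonyl carbon, gives an at least 1.5-fold lower number from compound 3 to compound 4 (0.18 log units; that floor lies within the scatter). Going by these compounds, compound 3 is held only as a limit, so this step is a floor, and its true size remains unknown.

The compounds shown leave open whether a bromine or a methoxy group on the aromatic ring would also give a reading, and whether a longer chain would change it. They also leave open whether 4-chlorophenyl would give a reading with benzylamino or 4-hydroxypiperidin-1-yl on the carbonyl carbon.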